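This account rests on a few compounds, and the source may have more. Where it says the series, first, only, none or still open, it means among the compounds named here.

Compound 3 `Oc1ccc2oc(Cc3ccccc3)cc2c1CN1CCC(N2CCCCC2)CC1` is the compound with the lowest number in a functional assay on SQ20B cells (Homo sapiens) for cytotoxicity, read by MTT assay, with a stated time of 72 h (on this read-out higher numbers stand for weaker inhibition and lower numbers for stronger inhibition), where compound 3 gives 3000 nM. Its nearest neighbour is compound 1 `Oc1ccc2oc(Cc3ccccc3)cc2c1CN1CCC(O)CC1`, which in this assay gives 13000 nM. Compound 2 `Oc1ccc2oc(Cc3ccccc3)cc2c1CN1CCC(c2ccccc2)CC1` is a different case: in this assay compound 2 gives only a limit, > 200000 nM, and no number (the limit of > 200000 nM in this assay, at which 1 of the 3 values shown sits).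

Within the data shown here, of the measured steps, the most useful is the one from the hydroxy compound to the piperidin-1-yl compound, giving a 4.3-fold lower number from compound 1 to compound 3 (0.64 log units; beyond the scatter). When phenyl enters in place of hydroxy at the same position, the result is an at least 15-fold higher number from compound 1 to compound 2 (1.18 log units; beyond the scatter), and from the phenyl compound to the piperidin-1-yl compound the data show an at least 66-fold lower number from compound 2 to compound 3 (1.82 log units; beyond the scatter).

Compound 4 `Oc1ccc2oc(Cc3ccccc3)cc2c1CN1CCC(N2CCCC2)CC1` differs from compound 3 by pyrrolidin-1-yl in place of piperidin-1-yl on a saturated ring carbon. Among the measured compounds shown here, no measured step exchanges one saturated nitrogen ring for another of a different size, so the comparison rests on the observation that a piperidin-1-yl at this position sits far from the phenyl limit and somewhat below hydroxy. Keeping a ring of the same kind, the expected step is a 1.2-fold higher number from compound 3 to compound 4 (0.07 log units; within the scatter), within the scatter. Compound 4 is therefore estimated at 3500 nM, with a range from 1400 nM to 9000 nM.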

Compound 4, half-maximal inhibitory concentration: 3000 nM
Beside the measured number, compound 4's estimate is 1.2-fold (0.07 log units) above it, within the range that was stated.
By their numbers in this assay, from the lowest: compounds 3 and 4 (each within the scatter of the next); then compound 1. At a limit, above all of these: compound 2.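

In this assay, pyrrolidin-1-yl in place of piperidin-1-yl on the saturated ring carbon gives no change at the digits printed from compound 3 to compound 4 (within the scatter), so at this position, three ring bonds from the ring nitrogen, the five-membered ring and the six-membered ring cannot be told apart. The same holds against hydroxy: the pyrrolidin-1-yl compound shows a 4.3-fold lower number from compound 1 to compound 4 (0.64 log units; beyond the scatter) and matches the step already seen with piperidin-1-yl, which means the lower number is not tied to one of these two ring sizes. Against phenyl, the data give an at least 66-fold lower number from compound 2 to compound 4 (1.82 log units; beyond the scatter), a step that is only bounded on one side since compound 2 sits at a limit of the assay: the limit of > 200000 nM in this assay, at which 1 of the 4 values shown sits.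

The compounds shown leave open whether the ring nitrogen is what separates these two compounds from compound 2, a question that a cyclohexyl group or an open-chain dimethylamino group at the same carbon would address. They also leave open whether a larger azepan-1-yl ring, or a morpholin-4-yl ring with its added oxygen, would stay at the same level.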